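This account rests on a few compounds, and the source may have more. Where it says the series, first, only, none or still open, it means among the compounds named here.

In a functional assay on U-251 cells (Homo sapiens) for cytotoxicity, read by sulforhodamine B assay, with a stated time of 48 h (a higher number here means a weaker inhibitor of growth, a lower number a stronger inhibitor of growth), compound 2, `ClCc1ccccc1Cn1cnc2nc(Cl)nc(Cl)c21`, gives 1170 nM, the lower of the two numbers recorded so far. Compound 1, `Nc1nc(Cl)c2ncn(Cc3ccc(CCl)cc3)c2n1`, gives 12000 nM in the same test, a higher number by a gap that lies beyond the usual scatter. Among the measured compounds shown here, compound 1 and compound 2 differ at more than one point, so their two values show only that compound 2 inhibits growth more strongly.

Compound 3, `ClCc1ccccc1Cn1cnc2ncnc(Cl)c21`, has not yet been measured. It differs from compound 2 in one place: hydrogen in place of chloro on an aromatic carbon. For the measured compounds named here, no measured pair in this set shows the effect of this particular change, so the size of the step can only be guessed from the two numbers above. The available values give no reason to expect a large movement in either direction in this assay; a modest shift toward a higher number, or none beyond the scatter, is the most cautious expectation. Compound 3 is therefore estimated at 2500 nM, with a plausible range from 800 nM to 8000 nM, which corresponds to an expected step of a 2.1-fold higher number from compound 2 to compound 3 (0.33 log units; beyond the scatter).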

Compound 3, concentration for total growth inhibition: 4360 nM
For compound 3 the middle estimate is 1.7-fold (0.24 log units) below the measured one, within the range that was stated.
By their numbers in this assay, from the lowest: compound 2; then compound 3; then compound 1.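

In this assay, replacing chloro with hydrogen on the aromatic carbon between two ring nitrogen atoms gives a 3.7-fold higher number from compound 2 to compound 3 (0.57 log units; beyond the scatter), so what this carbon carries matters to growth inhibition in these cells. Among the compounds shown here, compound 2 and compound 3 are the first pair in the set to differ in one place, which isolates this change in a way that the comparison of compound 1 with compound 2 could not, and here the chloro group goes with the stronger inhibition of growth. Nothing reported with these numbers accounts for the shift, so the step stands as an observation without an explanation.

The compounds shown leave open how an amine, a methoxy group or a bromo group on this same carbon would compare with chloro and hydrogen, and so whether the value of compound 2 can be improved on at this position. They also leave open whether exchanging the remaining chloro group on the same ring for an amine would move the number, and whether such a change would add to the step seen here or act independently of it.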